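Amide nitrogen change from compound 3 to compound 4

This account rests on a few compounds, and the source may have more. Where it says the series, first, only, none or still open, it means among the compounds named here.

Values in a functional assay on MDA-MB-435 cells (Homo sapiens) for cytotoxicity, read by MTT assay, with a stated time of 72 h; a higher number here means a weaker inhibitor, a lower number a stronger inhibitor:
- compound 1 `O=C(NCc1ccc(F)cc1)c1nc(NCCO)c2cccnc2c1O`: > 20000 nM (a limit of the assay, not a number)
- compound 2 `N[C@H]1CC[C@H](Nc2c(C(=O)NCc3ccc(Oc4ccccc4)cc3)nc(Br)c3cccnc23)CC1`: 4000 nM
- compound 3 `COc1cccc(CNC(=O)c2nc(Br)c3cccnc3c2N[C@H]2CC[C@H](N)CC2)c1`: 7000 nM

Compound 3 (7000 nM) and compound 2 (4000 nM) lie within the scatter of each other.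

Placing 1-(4-fluorophenyl)ethyl in place of 3-methoxybenzyl on an amide-type nitrogen turns compound 3 into compound 4 `C[C@H](NC(=O)c1nc(Br)c2cccnc2c1N[C@H]1CC[C@H](N)CC1)c1ccc(F)cc1` which has not yet been measured. Going by the values given here, no measured step tests this change. Starting from compound 3 (7000 nM) the expectation in this assay is for no step beyond the scatter. The estimated change is a 1.2-fold lower number from compound 3 to compound 4 (0.07 log units; within the scatter) and no more. For compound 4 the estimated value is 6000 nM (range 2500 nM to 15000 nM).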

Compound 4, half-maximal inhibitory concentration: > 10000 nM
Compound 4 ended at the assay's limit; the forecaster's own chance of this, stated with the estimate: 10%; middle value at least 1.6-fold (0.22 log units) away from the limit.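

In this assay, going by these compounds alone, the first one-place change on this amide-type nitrogen reads as an at least 1.4-fold higher number from compound 3 to compound 4 (0.15 log units; that floor lies within the scatter). Compound 4 gives > 10000 nM, which is a limit of the assay and not a number: the limit of > 10000 nM in this assay, at which 1 of the 4 values shown sits 1-(4-fluorophenyl)ethyl in place of 3-methoxybenzyl therefore shows no sign of a lower number at this position, but the size of the step stays unread.

From the compounds shown here alone, whether the branching methyl or the swap of methoxy for fluorine governs this outcome remains open. So does the effect of a phenylpropyl chain or a carboxylic acid on the benzyl ring at this nitrogen.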